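Swapping the dimethylamino ring for a dichlorophenyl ring

The source may report more compounds than this note shows. Statements on the series, on what has been measured and on what is new or still open speak of the compounds shown alone.

Measured compounds:
compound 1 `COc1cc(/C=C/C(=O)C2=C(/C=C/c3ccc(O)c(OC)c3)NC(=S)NC2c2ccccc2)ccc1O` – 50.4%
compound 2 `COc1cc(/C=C/C(=O)C2=C(/C=C/c3ccc(O)c(OC)c3)NC(=S)NC2c2ccc(C)cc2)ccc1O` – 41%
compound 3 `COc1cc(/C=C/C(=O)C2=C(/C=C/c3ccc(O)c(OC)c3)NC(=S)NC2c2ccc(N(C)C)cc2)ccc1O` – 84%

In a functional assay, with a stated time of 20 min, tested at 50 uM (on this read-out higher numbers stand for a stronger effect at the one concentration tested and lower numbers for a weaker effect), compound 3 gives the highest of the three numbers; its advantage over compound 1 and over compound 2 is beyond the scatter in both cases. Compound 4 `COc1cc(/C=C/C(=O)C2=C(/C=C/c3ccc(O)c(OC)c3)NC(=S)NC2c2c(Cl)cccc2Cl)ccc1O` differs from compound 3 in one place: 2,6-dichlorophenyl in place of 4-(dimethylamino)phenyl on a saturated ring carbon. Among the compounds with values here, two measured steps bear on this. The step of a number 33.6 percentage points higher from compound 1 to compound 3 (beyond the scatter) and the step of a number 43 percentage points higher from compound 2 to compound 3 (beyond the scatter) both show that putting a dimethylamino group on this ring raises the read-out strongly, while the step of a number 9.4 percentage points lower from compound 1 to compound 2 (within the scatter) shows a methyl there changes little. Removing the dimethylamino group is therefore expected to cost most of that gain, and the expected step is a number 39 percentage points lower from compound 3 to compound 4 (beyond the scatter). Compound 4 is estimated at 45%, ranging from 25% to 68%.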

Compound 4, a percentage reported as activity, at one concentration (the size of the read-out at that concentration, not a potency): 50%
Beside the measured number, compound 4's estimate is 5 percentage points below it, within the range that was stated.
By their numbers in this assay, from the lowest: compounds 2, 4 and 1 (each within the scatter of the next); then compound 3.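

In this assay, the 2,6-dichlorophenyl ring on this saturated ring carbon does not keep the level of the 4-(dimethylamino)phenyl ring (a number 34 percentage points lower from compound 3 to compound 4 (beyond the scatter)). Beside the phenyl ring (a number 0.4 percentage points lower from compound 1 to compound 4 (within the scatter)) and the 4-methylphenyl ring (a number 9 percentage points higher from compound 2 to compound 4 (within the scatter)), the change stays within the scatter, so of these four compounds only compound 3 stands apart. No measurement shown here accounts for this result.

Going by these compounds, it remains open whether a plain amino group or a morpholine on this ring would give a read-out like that of compound 3. A single chlorine on the ring is also untested by these compounds.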